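The source may report more compounds than this note shows. Statements on the series, on what has been measured and on what is new or still open speak of the compounds shown alone.

Measured compounds:
compound 1, `C=Cc1c(CC)nn(CCCN2CCN(c3ccc(C)cc3)CC2)c(=O)c1N`: 28%
compound 2, `COc1cccc(N2CCN(CCCn3nc(-c4ccccc4)c(C#N)c3C)CC2)c1`: 34%
compound 3, `CC(=O)c1cccn1CCCN1CCN(c2ccc(F)cc2)CC1`: 38%

All three numbers come from a functional assay on the whole organism (Abdomen, strain Swiss) for inhibition, with Mus musculus as the target, with stated times of 30 min, 10 min and 5 min, at a dose of 40 mg/kg by the oral route; on this read-out lower numbers stand for a weaker effect and higher numbers for a stronger effect at the one dose given. Compound 3 stands highest of the three numbers shown; the nearest is compound 2, the furthest compound 1, and both gaps lie within the scatter, so the three compounds cannot be ranked against each other on these data. Compound 2 and compound 1 carry other groups on the ring nitrogen and differ from compound 3 in more than one place, so their values show only that the three lie close together.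

Compound 4, `CC(=O)c1cccn1CCCN1CCN(c2cccc(Cl)c2)CC1`, has not yet been measured in this assay. It differs from compound 3 in one place: 3-chlorophenyl in place of 4-fluorophenyl on an amine nitrogen in a ring. Among the compounds with values here, no pair of measured compounds differs in this place alone, so the size of this step cannot be taken from a measured step. The change swaps one halogen-bearing phenyl for another on an amine nitrogen in a ring, and the three measured compounds with different groups at that position all sit within the scatter of each other. For this assay the step of a number 3 percentage points lower from compound 3 to compound 4 (within the scatter) is therefore expected to stay within the scatter, with no clear direction. Compound 4 is estimated at 35%, in the range 15% to 55%.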

Compound 4, a percentage reported as inhibition, in the whole organism at one dose (the size of the read-out at that dose, not a potency): 54%
Beside the measured number, compound 4's estimate is 19 percentage points below it; measured number inside the range.
By their numbers in this assay, from the lowest: compounds 1, 2 and 3 (each within the scatter of the next); then compound 4.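

In this assay the group on the amine nitrogen of the six-membered ring turns out to be a place where a single change can be read: 3-chlorophenyl in place of 4-fluorophenyl gives a number 16 percentage points higher from compound 3 to compound 4 (beyond the scatter) on an otherwise unchanged structure. The earlier compounds shown here could not show this, since they differ from compound 3 in more than one place and their close values said nothing about this position alone. The swap leaves the count of heavy atoms, the ring type and the hydrogen-bond counts of the group unchanged, so those counted features do not separate 3-chlorophenyl from 4-fluorophenyl, and nothing measured here gives a reason for the step.

The step changes both the halogen and the place it occupies on the phenyl ring, so the two cannot be told apart from this one pair, and a 4-chlorophenyl or a 3-fluorophenyl group at this position would be needed to divide them. From the compounds shown here alone, the read-out is also the size of the effect at one dose, so how compound 4 compares with compound 3 across doses stays open.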